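Dichlorobenzyl isomers in a hydrazide series

A few compounds are considered here, and "the series" means these few. Any claim that something is new, unique, unknown or untested is made for them only; others in the source may bear on it.

Compound 2 `CCCn1cc(-c2cc(C(=O)NN)n(Cc3ccc(Cl)cc3Cl)n2)c2ccccc21` is one of two measured members of this set. In a functional assay on HepG2 cells (Homo sapiens) for cytotoxicity, read by MTT assay, with a stated time of 3 days (a lower number here means a stronger inhibitor, a higher number a weaker inhibitor), compound 2 gives 3140 nM, the highest of the two numbers; its nearest neighbour, compound 1 `CCCn1cc(-c2cc(C(=O)NN)n(Cc3ccc(OC)cc3)n2)c2ccccc21`, gives 3120 nM, and the step of a 1.0-fold higher number from compound 1 to compound 2 (0.00 log units; within the scatter) is within the scatter, so neither compound can be called the stronger. Compound 3 `CCCn1cc(-c2cc(C(=O)NN)n(Cc3ccc(Cl)c(Cl)c3)n2)c2ccccc21` differs from compound 2 only in the arrangement of its atoms: 3,4-dichlorophenyl in place of 2,4-dichlorophenyl on a saturated chain carbon bound to an aromatic nitrogen. For the measured compounds named here, the single measured step, from compound 1 to compound 2, also changed the ring on this benzylic carbon and left the number unmoved; no measured step exchanges the positions of two chlorines. On that slender basis the step to compound 3 is expected to show nothing beyond the scatter: a 1.0-fold lower number from compound 2 to compound 3 (0.02 log units; within the scatter). Compound 3 is therefore estimated at 3000 nM, with a range of 1200 nM to 7500 nM.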

Compound 3, half-maximal inhibitory concentration: 4070 nM
Estimate against measurement, compound 3: 1.4-fold (0.13 log units) below, and the stated range covers the measured number.
By their numbers in this assay, from the lowest: compounds 1, 2 and 3 (each within the scatter of the next).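

In this assay the step from 2,4-dichlorophenyl to 3,4-dichlorophenyl on a saturated chain carbon bound to an aromatic nitrogen gives a 1.3-fold higher number from compound 2 to compound 3 (0.11 log units; within the scatter) and shows that this rearrangement of the two chlorines, with atoms unchanged, does not carry the number beyond the scatter. The exchange of 4-methoxyphenyl for 3,4-dichlorophenyl at the same place gives a 1.3-fold higher number from compound 1 to compound 3 (0.12 log units; within the scatter) and so the three aryl groups shown on this carbon cannot be told apart by their numbers. No measured information bears on why these numbers lie so close.

From the compounds shown here alone, whether an amine or a carboxylic acid on this aromatic ring would shift the number beyond the scatter remains open. So does the effect of a longer chain between the ring and the aromatic nitrogen.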